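The source may hold more compounds than are shown below. What is called first, only, known or untested is meant among the compounds shown, and "the series" means these compounds.

Measured so far in a functional assay on OVCAR-3 cells (Homo sapiens) for inhibition; a higher number here means a weaker inhibitor, a lower number a stronger inhibitor:
- compound 1, `N#CC1CN1C(=O)Nc1ccc(Cl)cc1Cl`: 35000 nM
- compound 2, `N#CC1CN1C(=O)Nc1ccc(S(N)(=O)=O)cc1`: 188000 nM
- compound 3, `CCCCNC(=O)N1CC1C#N`: 12000 nM

Compound 3 stands lowest of the three numbers in this assay, which makes it the strongest inhibitor of the set: its gap to compound 1 lies beyond the scatter, and its gap to compound 2 lies well beyond it. Among the measured compounds shown here, the three measured compounds differ from one another in more than one place, so no single-change step between measured compounds is available, and the two aryl ureas say nothing direct about a change within the alkyl group of compound 3.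

Compound 4, `CC(C)(C)NC(=O)N1CC1C#N`, is the next compound to be measured. It differs from compound 3 by tert-butyl in place of butyl on an amide-type nitrogen, the same atoms joined differently. For the measured compounds named here, with no comparable step among the measured compounds, the expectation rests on the small size of the change alone: a step of no more than the scatter is expected, if anything toward a slightly higher number. Compound 4 is estimated at 15000 nM in this assay, with a range from 5000 nM to 45000 nM, meaning an expected step of a 1.3-fold higher number from compound 3 to compound 4 (0.10 log units; within the scatter).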

Compound 4, half-maximal inhibitory concentration: 186000 nM
Compound 4: the middle estimate sits 12-fold (1.09 log units) below what was measured; the measured number lies above the stated range.
By their numbers in this assay, from the lowest: compound 3; then compound 1; then compounds 4 and 2 (each within the scatter of the next).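

In this assay, among the compounds shown here, tert-butyl in place of butyl on the amide-type nitrogen gives a 16-fold higher number from compound 3 to compound 4 (1.19 log units; beyond the scatter) and so marks this position as sensitive to how the group is joined, which the earlier compounds could not show, as compound 1 and compound 2 each differ from compound 3 in more than one place. The two groups have the same atoms, no ring, and no net charge, so this large step comes from a change in connectivity alone, with no atom gained or lost. The compounds shown offer no measurement that accounts for the size of the step.

From the compounds shown here alone, it remains open whether isobutyl or sec-butyl, the same atoms joined in other ways, would stay close to compound 3 or move toward compound 4, and so whether the loss follows the degree of branching or belongs to tert-butyl alone. Also open, going by these compounds, is how a shorter chain such as ethyl, a longer chain such as hexyl, or a cyclohexyl group would read on this nitrogen.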